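The source may hold more compounds than are shown below. What is called first, only, known or untested is meant among the compounds shown, and "the series" means these compounds.

Going by the values given here, in a functional assay on PC-3 cells (Homo sapiens) for cytotoxicity, read by WST assay, with a stated time of 48 h (on this read-out lower numbers stand for stronger inhibition and higher numbers for weaker inhibition), compound 2 (`COc1ccc2c(C(=O)/C(C#N)=C/c3c[nH]c4ccccc34)c[nH]c2c1`) gives 12000 nM as the only actual number so far. Compound 1 (`COc1ccc2c(C(=O)/C(C#N)=C/c3cn(Cc4ccc(Cl)cc4)c4ccccc34)c[nH]c2c1`) gives > 50000 nM and this is a limit of the assay, not a number.

Compound 3 (`COc1ccc(Cn2cc(/C=C(\C#N)C(=O)c3c[nH]c4cc(OC)ccc34)c3ccccc32)cc1`) follows from compound 2 with 4-methoxybenzyl in place of hydrogen on an aromatic nitrogen and the rest of the structure unchanged. Among the compounds with values here, one measured step bears on this change: an at least 4.1-fold lower number from compound 1 to compound 2 (0.61 log units; beyond the scatter) on replacing 4-chlorobenzyl with hydrogen on that nitrogen. Compound 1 is the only measured case with a benzyl group there, so the evidence is a single pair, and its step runs in the opposite direction to the one now in question. On the strength of an at least 4.1-fold lower number from compound 1 to compound 2 (0.61 log units; beyond the scatter) alone, a higher number and thus weaker inhibition is expected for compound 3 in this assay as well. The expected size is a 2.5-fold higher number from compound 2 to compound 3 (0.40 log units; beyond the scatter) as a rough estimate. The result may also come back only as a limit, as in the limit of > 50000 nM in this assay, at which 1 of the 2 values shown sits, for this series. For compound 3 the estimated value is 30000 nM (expected range 9000 nM to 90000 nM).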

Compound 3, half-maximal inhibitory concentration: > 50000 nM
Compound 3 was reported as a limit (the forecaster's own chance of this, stated with the estimate: 50%); middle value at least 1.6-fold (0.22 log units) from the limit.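

In this assay, the effect of a benzyl group on this aromatic nitrogen no longer rests on compound 1 alone: an at least 4.1-fold higher number from compound 2 to compound 3 (0.61 log units; beyond the scatter). With 4-methoxybenzyl as with 4-chlorobenzyl, the result is a limit and not a number, so among the compounds shown, a readable value appears only with hydrogen at this position, in compound 2. Methoxy in place of chloro on the benzyl ring cannot be read from compound 1 to compound 3, as both results are limits and give no order between the two groups: the limit of > 50000 nM in this assay, at which 2 of the 3 values shown sit.

Compound 2, at 12000 nM, therefore remains the only reference point. The compounds shown do not tell how far the two benzyl compounds lie past the limit. Also open, as far as these compounds go, is whether a methyl group, or a short chain ending in an amine or a carboxylic acid, on this nitrogen would give a readable number or would likewise end at the limit.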